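A Methoxyphenyl Hydrazone Against a Weakly Active Series

This account rests on a few compounds, and the source may have more. Where it says the series, first, only, none or still open, it means among the compounds named here.

Compound 1 `Cc1c(C(=O)N/N=C\c2ccccc2F)oc2cccc(O)c12` is one of three aryl hydrazones of the shared core tested in a functional assay on PC-3 cells (Homo sapiens) for inhibition; on this read-out higher numbers stand for weaker inhibition and lower numbers for stronger inhibition. For compound 1 the result is a limit of the assay, >= 40000 nM, and not a number. Compound 3 `Cc1c(C(=O)N/N=C\c2ccncc2)oc2cccc(O)c12` is likewise reported only as a limit in this assay, >= 40000 nM. Within the data shown here, compound 2 `Cc1c(C(=O)N/N=C\c2ccccc2O)oc2cccc(O)c12` is the sole member with a numerical value: in this assay compound 2 gives 8350 nM. The step of an at least 4.7-fold lower number from compound 1 to compound 2 (0.68 log units; beyond the scatter) shows compound 1 to be weaker than compound 2, and the step of an at least 4.7-fold higher number from compound 2 to compound 3 (0.68 log units; beyond the scatter) shows that only compound 2 lies off the limit; the step that the two limits leave unreadable from compound 1 to compound 3 cannot be read because of the limit of >= 40000 nM in this assay, at which 2 of the 3 values shown sit.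

Compound 4 `COc1cccc(/C=N\NC(=O)c2oc3cccc(O)c3c2C)c1` is the unmeasured member. It differs from compound 1 as 3-methoxyphenyl in place of 2-fluorophenyl on a carbon with a double bond to nitrogen. Among the measured compounds shown here, no measured step exchanges a 2-fluorophenyl for a 3-methoxyphenyl, so the nearest guide is the step from compound 1 to compound 2, where hydroxy in place of fluoro produced the only number in the set. Compound 4 carries a methoxy rather than a hydroxy, and compound 4 is therefore expected to shift an at least 1.3-fold lower number from compound 1 to compound 4 (0.12 log units; that floor lies within the scatter) at most, most probably remaining close to the limit. The estimate for compound 4 in this assay is 30000 nM, within 9000 nM to 80000 nM.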

Compound 4, half-maximal inhibitory concentration: >= 40000 nM
Compound 4: no number, only a limit; the forecaster's own chance of this, stated with the estimate: 55%; at least 1.3-fold (0.12 log units) between middle value and limit.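

Exchanging the 2-hydroxyphenyl of compound 2 for a 3-methoxyphenyl on the carbon with a double bond to nitrogen gives an at least 4.7-fold higher number from compound 2 to compound 4 (0.68 log units; beyond the scatter), so this change loses the measurable inhibition seen in this assay. Compound 4 carries an oxygen on its aromatic ring, yet among the four compounds shown, compound 2 remains the only one with a number, so an oxygen on that ring does not by itself give a measurable value. The steps among compound 1, compound 3 and compound 4 cannot be read, and their order stays unknown, because all three sit at the same limit: the limit of >= 40000 nM in this assay, at which 3 of the 4 values shown sit.

As far as these compounds go, what a 2-methoxyphenyl or a 3-hydroxyphenyl would give on this carbon stays open, and with it whether the hydroxy itself or its place on the ring sets compound 2 apart. Also open, from the compounds shown here alone, is whether a group such as an aminophenyl or a carboxyphenyl at this position would give a number in this assay.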